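A ring exchange on compound 1

The source may report more compounds than this note shows. Statements on the series, on what has been measured and on what is new or still open speak of the compounds shown alone.

Measured in an ADME assay on MDCK-II cells (Canis lupus familiaris) for permeability; on this read-out higher numbers stand for higher permeability and lower numbers for lower permeability:
- compound 1 `CC(C)Oc1cc(Oc2ccc(S(C)(=O)=O)cc2)cc(-c2cncc(=O)[nH]2)c1` gives 94 10^-6 cm/s
- compound 2 `CC(C)Oc1cc(Oc2cnc(C(=O)N(C)C)nc2)cc(-c2nccc(=O)[nH]2)c1` gives 7.1 10^-6 cm/s
- compound 3 `CCS(=O)(=O)c1ccc(Oc2cc(O[C@@H](C)CO)cc(-c3nccc(=O)[nH]3)c2)cc1` gives 2.8 10^-6 cm/s

Compound 1 stands highest of the three, and the gaps down to compound 2 and to compound 3 both lie beyond the scatter. Compound 4 `CCc1cnc(-c2cc(Oc3ccc(S(C)(=O)=O)cc3)cc(OC(C)C)c2)[nH]c1=O` differs from compound 1 in one place (a group of 9 heavy atoms (6 carbon, 2 nitrogen, 1 oxygen; one six-membered aromatic ring with 2 hetero atoms) in place of a group of 7 heavy atoms (4 carbon, 2 nitrogen, 1 oxygen; one six-membered aromatic ring with 2 hetero atoms), on an aromatic carbon), and the rest of the structure stays unchanged. Going by the values given here, no measured pair shows this exchange alone: compound 2 and compound 3 each differ from compound 1 in more than one place. The expectation therefore starts from compound 1 at 94 10^-6 cm/s and allows for only a modest shift. In this assay the expected change is a small fall that stays within the scatter, an estimated 1.3-fold lower number from compound 1 to compound 4 (0.13 log units; within the scatter). Among the compounds with values here, with no direct precedent, the range is kept wide. The estimate for compound 4 is 70 10^-6 cm/s, with an expected range from 30 10^-6 cm/s to 130 10^-6 cm/s.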

Compound 4, apparent permeability: 4 10^-6 cm/s
Estimate against measurement, compound 4: 18-fold (1.24 log units) above, and the stated range ends above it.
By their numbers in this assay, from the lowest: compounds 3, 4 and 2 (each within the scatter of the next, the first and the last beyond it); then compound 1.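

In this assay, the exchange on an aromatic carbon of a six-membered aromatic ring of carbon only, meta to an isopropoxy group, gives a 24-fold lower number from compound 1 to compound 4 (1.37 log units; beyond the scatter). This is the first single-place change shown, and it makes clear that this position can move the read-out by a large step. The two groups match in hydrogen-bond donors, hydrogen-bond acceptors and net charge and differ in size, 9 heavy atoms in place of 7, yet nothing measured here accounts for the fall.

Whether the fall follows the added carbon or the different ring of the entering group remains open, with only this one exchange shown at this position. Also open, going by these compounds, is how the same ring would read in this assay carrying an amine, a carboxylic acid or a longer chain.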